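Replacing Phenyl With 3-Chloro-4-hydroxyphenyl in Compound 1

The source may report more compounds than this note shows. Statements on the series, on what has been measured and on what is new or still open speak of the compounds shown alone.

Measured compounds:
compound 1 `CS(=O)(=O)c1ccc(N2N=C(c3ccccc3)CCC2=O)cc1`: 26.6%
compound 2 `CS(=O)(=O)c1ccc(N2N=C(c3ccc(-c4ccccc4)cc3)CCC2=O)cc1`: 6.6%

In a functional assay on the whole organism (strain Wistar) for inhibition, with Rattus norvegicus as the target, read by paw edema, with stated times of 30 min and 3 h, at a dose of 0.05 mmol/kg by the oral route (on this read-out higher numbers stand for more inhibition at the one dose given (going by the name of the read-out) and lower numbers for less inhibition), compound 1 gives 26.6%, the higher of the two numbers measured, and compound 2, the nearest, gives 6.6%. Within the data shown here, the one measured step, a number 20 percentage points lower from compound 1 to compound 2 (beyond the scatter), came from phenyl in place of hydrogen on an aromatic carbon of the ring that hangs from the core of compound 1.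

Compound 3 `CS(=O)(=O)c1ccc(N2N=C(c3ccc(O)c(Cl)c3)CCC2=O)cc1` differs from compound 1 by 3-chloro-4-hydroxyphenyl in place of phenyl on a carbon with a double bond to nitrogen. The measured step bears on this only loosely: both changes add to the same aromatic ring, and in the one case recorded a larger addition lowered inhibition. For compound 3 a smaller drop, possibly none beyond the scatter, is therefore expected, a number 8.6 percentage points lower from compound 1 to compound 3 (within the scatter). Compound 3 is estimated to give 18%, within a range from 5% to 32%.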

Compound 3, a percentage reported as inhibition, in the whole organism at one dose (the size of the read-out at that dose, not a potency): 43.3%
Compound 3: the middle estimate sits 25.3 percentage points below what was measured, outside the stated range (above it).
By their numbers in this assay, from the lowest: compound 2; then compound 1; then compound 3.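

In this assay the phenyl on the carbon with a double bond to nitrogen proves open to a gain as well as a loss: 3-chloro-4-hydroxyphenyl in its place gives a number 16.7 percentage points higher from compound 1 to compound 3 (beyond the scatter) and the core of compound 1 stays unchanged. Set against a number 20 percentage points lower from compound 1 to compound 2 (beyond the scatter) on the same ring, this shows that the direction of the step here depends on what is added, and not merely on something being added. No measurement at hand accounts for the rise.

Still open, on these data alone, is which of the two additions, the chlorine or the hydroxy group, goes with the rise, as each appears here only alongside the other. Also open, as far as these compounds go, is how a methoxy group or a carboxylic acid in place of the hydroxy group, or a fluorine in place of the chlorine, would fare.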